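Adding a Trifluoromethyl Group Beside an Aryl Chloride

This account rests on a few compounds, and the source may have more. Where it says the series, first, only, none or still open, it means among the compounds named here.

Compound 1, whose structure is `O=C(Nc1ccc(Oc2ccnc3[nH]ccc23)cc1)c1nn(-c2ccc(Cl)cc2)ccc1=O`, is one of two compounds tested in a functional assay on A549 cells (Homo sapiens) for cytotoxicity, read by MTT assay, with a stated time of 72 h; on this read-out higher numbers stand for weaker inhibition and lower numbers for stronger inhibition. In this assay compound 1 gives 25100 nM, the lowest of the two numbers shown, meaning the stronger inhibition of the pair. Its partner, compound 2 with structure `COc1ccc(-n2ccc(=O)c(C(=O)Nc3ccc(Oc4ccnc5[nH]ccc45)cc3)n2)cc1`, gives 53100 nM in this assay. Among the measured compounds shown here, the only measured step, a 2.1-fold higher number from compound 1 to compound 2 (0.33 log units; beyond the scatter), replaces the chloro group with methoxy.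

The compound not yet measured, compound 3, has structure `O=C(Nc1ccc(Oc2ccnc3[nH]ccc23)cc1)c1nn(-c2ccc(Cl)c(C(F)(F)F)c2)ccc1=O`. It differs from compound 1 by trifluoromethyl in place of hydrogen on an aromatic carbon, so that the 4-chlorophenyl becomes 4-chloro-3-(trifluoromethyl)phenyl while the chloro group itself is kept. For the measured compounds named here, no measured step changes this position, and the single known step concerns a different exchange on the same ring, so it gives no direct guide to the direction here. The expectation for compound 3 is therefore a step no larger than modest in this assay, written as a 1.7-fold lower number from compound 1 to compound 3 (0.22 log units; within the scatter), with either direction possible. Compound 3 is estimated at 15000 nM, within a range from 5000 nM to 50000 nM.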

Compound 3, half-maximal inhibitory concentration: 2190 nM
Compound 3: the middle estimate sits 6.8-fold (0.84 log units) above what was measured, and the stated range ends above it.
By their numbers in this assay, from the lowest: compound 3; then compound 1; then compound 2.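

In this assay, adding trifluoromethyl on an aromatic carbon ortho to a chloro group, with the chloro group kept, gives an 11-fold lower number from compound 1 to compound 3 (1.06 log units; beyond the scatter) and so a large step, whereas the earlier exchange of chloro for methoxy gave only a modest one. Among the compounds shown here, this shows that a ring carbon untouched by the earlier compounds can shift the number strongly, and that a substituent need not replace the chloro group to do so. The full exchange of 4-methoxyphenyl for 4-chloro-3-(trifluoromethyl)phenyl on an aromatic nitrogen gives a 24-fold lower number from compound 2 to compound 3 (1.38 log units; beyond the scatter) as another large step, but nothing available here explains why either change has this effect.

As far as these compounds go, it remains open whether this shift is particular to trifluoromethyl or would also appear with a methyl group, a bromine atom or a nitrile on the same carbon. From the compounds shown here alone, it is also open whether trifluoromethyl would have a similar effect with hydrogen or methoxy in place of the chloro group, which would show whether the two groups must be present together.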